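Adding a dimethylaminoethyl Chain to the Methoxy of Compound 1

A few compounds are considered here, and "the series" means these few. Any claim that something is new, unique, unknown or untested is made for them only; others in the source may bear on it.

Three close relatives have been tested in a toxicity assay on Huh-7.5 cells (Homo sapiens) for inhibition, read by MTT assay, with a stated time of 96 h; a higher number here means that more compound is tolerated, a lower number that less compound is tolerated. Compound 1 `CCC(=O)Nc1cc(C(=O)Nc2ccc(OC)cc2)ccc1OC` gives 109000 nM. Compound 2 `CCC(=O)Nc1cc(C(=O)Nc2ccc(N(C)C)cc2)ccc1OC` gives 171000 nM, and compound 3 `CCC(=O)Nc1cc(C(=O)Nc2ccc(-c3cc4ccccc4[nH]3)cc2)ccc1OC` gives 65600 nM. Among these three numbers compound 1 stands second highest: a 1.6-fold higher number from compound 1 to compound 2 (0.20 log units; within the scatter), and a 1.7-fold lower number from compound 1 to compound 3 (0.22 log units; within the scatter), so neither neighbour is clearly separated from it. For the measured compounds named here, only the step between the other two is larger, as a 2.6-fold lower number from compound 2 to compound 3 (0.42 log units; beyond the scatter).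

Compound 4 `CCC(=O)Nc1cc(C(=O)Nc2ccc(OC)cc2)ccc1OCCCN(C)C` differs from compound 1 at a different place from any of these steps: 2-(dimethylamino)ethyl in place of hydrogen on a saturated chain carbon bound to an oxygen on an aromatic ring. The three measured steps all swap the group on the far aromatic ring of the amide, whereas the change to compound 4 lengthens the methoxy that sits on the shared core, leaving the amide side untouched. Going by the values given here, no measured step therefore speaks directly to this change; the only guidance is that the three known compounds all sit within a narrow band of tolerance, and exchanges on the aromatic periphery shifted the number little.

In this assay compound 4 is therefore expected to give 100000 nM, with a range of 40000 nM to 250000 nM, meaning a step of a 1.1-fold lower number from compound 1 to compound 4 (0.04 log units; within the scatter) that is expected to stay within the scatter.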

Compound 4, half-maximal cytotoxic concentration: 154000 nM
For compound 4 the middle estimate is 1.5-fold (0.19 log units) below the measured one; measured number inside the range.
By their numbers in this assay, from the lowest: compounds 3, 1, 4 and 2 (each within the scatter of the next, the first and the last beyond it).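

Until now, every measured step had swapped the group on the far aromatic ring, so nothing had tested the methoxy on the shared core in this assay. Compound 4 turns that methoxy into 3-(dimethylamino)propoxy, and the step, a 1.4-fold higher number from compound 1 to compound 4 (0.15 log units; within the scatter), shows that this large addition, which brings an amine onto the chain, leaves compound 4 indistinguishable from compound 1 in how much compound the cells tolerate. So this position on the core, like the far ring in the earlier compounds, has so far produced no clear separation from compound 1, although no supporting measurement explains this result.

The compounds shown test only one chain length with one end group at this position, so it remains open whether a longer chain, or a carboxylic acid or a morpholine at the chain's end, would stay as close to compound 1. Also open, as far as these compounds go, is how the 3-(dimethylamino)propoxy group would behave alongside the 1H-indol-2-yl group of compound 3, the compound with the lowest number of the series.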